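A few compounds are considered here, and "the series" means these few. Any claim that something is new, unique, unknown or untested is made for them only; others in the source may bear on it.

Compound 1 `O=C(C(Nc1ccccc1F)c1ccc(C(F)(F)F)cc1)N1CCCC1c1ccccc1Cl` gives 11 nM in an assay on HEK293 cells for antagonist activity at transient receptor potential M8 protein (Canis lupus familiaris), read by fluorescence and calcium flux, with a stated time of 5 min; on this read-out lower numbers stand for stronger inhibition and higher numbers for weaker inhibition; compound 2 `COc1ccccc1C1CCCN1C(=O)C(Nc1ccccc1F)c1ccc(C(F)(F)F)cc1` gives 12 nM.

Compound 2 therefore stands highest of the two numbers, though its gap to compound 1 is within the scatter: a 1.1-fold higher number from compound 1 to compound 2 (0.04 log units; within the scatter). Compound 3 `O=C(C(Nc1ccccc1F)c1ccc(C(F)(F)F)cc1)N1CCCC1c1ccncc1` differs from compound 2 by pyridin-4-yl in place of 2-methoxyphenyl on a saturated ring carbon. For the measured compounds named here, no measured step bears directly on this change; the only step known swaps one substituent on that aromatic ring and stays within the scatter, so nothing shows how loss of the whole substituted phenyl is tolerated. A weakening step is expected, a 5.0-fold higher number from compound 2 to compound 3 (0.70 log units; beyond the scatter), and compound 3 is estimated at 60 nM, between 15 nM and 300 nM.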

Compound 3, half-maximal inhibitory concentration: 19 nM
The estimate for compound 3 lay 3.2-fold (0.50 log units) above the measured number, within the range that was stated.
By their numbers in this assay, from the lowest: compounds 1, 2 and 3 (each within the scatter of the next).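

The earlier compounds shown here showed only one substituent on the phenyl ring exchanged for another. Here the whole 2-methoxyphenyl gives way to pyridin-4-yl on the saturated ring carbon next to the ring nitrogen, and in this assay the step stays within the scatter (a 1.6-fold higher number from compound 2 to compound 3 (0.20 log units; within the scatter)), as does the exchange for 2-chlorophenyl (a 1.7-fold higher number from compound 1 to compound 3 (0.24 log units; within the scatter)). Among these three compounds, then, neither an aromatic ring of carbon only nor a substituent on it is required at this position, and no supporting evidence accounts for this. Still open, going by these compounds, is whether pyridin-3-yl would read the same, and whether a non-aromatic group such as morpholine or a plain methyl would be accepted on this carbon.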